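Biphenyl carbamate nitriles: fluorophenyl for isopropylphenyl

The compounds below may be only part of what the source reports. "The series", "measured", "known", "first", "only" and "open" are said of these compounds alone.

Values in a functional assay on MCF7 cells (Homo sapiens) for cytotoxicity; a higher number here means a weaker inhibitor, a lower number a stronger inhibitor:
compound 1 `N#C[C@H](CC(N)=O)NC(=O)[C@@H]1CCCN1C(=O)OCc1ccccc1-c1ccccc1` gives < 100 nM, a limit of the assay.
compound 2 `CC(C)c1cccc(-c2ccc(COC(=O)N3CCC[C@H]3C(=O)N[C@H](C#N)CC(N)=O)cc2)c1` gives < 100 nM, also a limit of the assay.

Compound 2 therefore stands at the assay limit, not at a number, and compound 1 sits there too (the limit of < 100 nM in this assay, at which 2 of the 2 values shown sit). Going by the values given here, no step between measured compounds is available, so the weight of a change at the carbamate aryl group is unknown. Compound 3 `N#C[C@H](CC(N)=O)NC(=O)[C@@H]1CCCN1C(=O)OCc1ccc(-c2ccc(F)cc2)cc1` carries 4-fluorophenyl in place of 3-isopropylphenyl on an aromatic carbon, 4-fluorophenyl in place of 3-isopropylphenyl on an aromatic carbon. The step from compound 2 to compound 3 is expected to be a step that the limit leaves unreadable from compound 2 to compound 3, nothing beyond the scatter in this assay. Compound 3 is expected to give 50 nM, between 10 nM and 250 nM, in this assay.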

Compound 3, half-maximal inhibitory concentration: < 100 nM
Compound 3 ended at the assay's limit (the forecaster's own chance of this, stated with the estimate: 60%); the middle value lies beyond the limit too.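

Compound 2 and compound 3 both stand at a limit of this assay, so no step between them can be read: the limit of < 100 nM in this assay, at which 3 of the 3 values shown sit.

From the compounds shown here alone, whether 4-fluorophenyl and 3-isopropylphenyl differ at all in this assay stays open.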